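Chloro on the phenyl of compound 1

The compounds below may be only part of what the source reports. "The series", "measured", "known", "first", "only" and "open" are said of these compounds alone.

In an ADME assay on microsomes from liver (Homo sapiens) for metabolic stability, read by LC-MS, using NADPH, tested at 1 uM (on this read-out higher numbers stand for a longer-lived compound and lower numbers for a shorter-lived compound), compound 1 `N#Cc1cnc(NC(=O)CCCOc2ccccc2)s1` gives 0.15 h. Among the compounds with values here, the only other measured compound, compound 2 `Cc1cnc(NC(=O)CCCOc2ccccc2)s1`, gives 0.167 h. These two values lie within the scatter of each other, so neither compound can be ranked above the other. Compound 3 `N#Cc1cnc(NC(=O)CCCOc2cccc(Cl)c2)s1` keeps the core of compound 1 and differs in one place: chloro in place of hydrogen on an aromatic carbon. This is chloro in place of hydrogen on an aromatic carbon, or phenyl to 3-chlorophenyl.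

Within the data shown here, only one measured step is available, and it bears on this change only loosely: a 1.1-fold higher number from compound 1 to compound 2 (0.05 log units; within the scatter). That step put methyl in place of cyano, which is a different group from the one now altered. Among the measured compounds shown here, no measured compound carries chloro, so the data give no direct reading of this change and no firm direction. With so little to go on, no large move is expected in this assay. The expected step is a 1.1-fold higher number from compound 1 to compound 3 (0.03 log units; within the scatter), which would be none beyond the scatter. The estimate for compound 3 is 0.16 h, with an expected range from 0.08 h to 0.32 h.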

Compound 3, half-life: 0.25 h
For compound 3 the middle estimate is 1.6-fold (0.19 log units) below the measured one, within the range that was stated.
By their numbers in this assay, from the lowest: compounds 1, 2 and 3 (each within the scatter of the next).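

With chloro in place of hydrogen on an aromatic carbon, phenyl to 3-chlorophenyl, the reading in this assay is a 1.7-fold higher number from compound 1 to compound 3 (0.22 log units; within the scatter) and gives the first view of the phenyl end of the series, since the earlier pair differed only at the cyano. The place meta to a large group therefore takes a chlorine without a step beyond the scatter, and all that these three compounds support is that this one change leaves the half-life within the range of repeat measurements. No measured property of these compounds bears on this result, and the reading comes with no explanation.

On these data alone, whether chloro elsewhere on the phenyl would read the same, or whether methoxy, an amine or a carboxylic acid at this place would move the half-life beyond the scatter, stays open. Also open, as far as these compounds go, is whether chloro would read the same on compound 2, which carries methyl in place of cyano, and what a longer chain would do in the same assay.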